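Removing the methoxy from the carboxylic acid ring of compound 2

The source may report more compounds than this note shows. Statements on the series, on what has been measured and on what is new or still open speak of the compounds shown alone.

Compound 2 `COc1cc(C(=O)O)ccc1OCCCCOc1ccc(C(=O)CC(C)C)c(O)c1C` gives 43% in an ADME assay (liver) for metabolic stability, with Liver microsome (Rattus norvegicus) as the target, read by LC-MS, using microsomes and NADPH, with stated times of 5 min and 60 min, tested at 4 uM; on this read-out lower numbers stand for a less stable compound and higher numbers for a more stable compound. Among the three compounds measured, compound 2 stands second highest: compound 1 `COc1cc(C(=O)O)ccc1OCCCCOc1ccc(C(=O)CC(C)(C)C)c(O)c1C` gives 49%, and the step of a number 6 percentage points lower from compound 1 to compound 2 (within the scatter) lies within the scatter; compound 3 `Cc1c(OCCCCOc2ccc(C(=O)O)cc2Cl)ccc(C(=O)CC2CCCC2)c1O` gives 21%, the lowest of the three and beyond the scatter from compound 2. Compound 4 `Cc1c(OCCCCOc2ccc(C(=O)O)cc2)ccc(C(=O)CC(C)C)c1O` differs from compound 2 in one place: hydrogen in place of methoxy on an aromatic carbon. Within the data shown here, the only measured step, that from compound 1 to compound 2, concerns a chain carbon and not the aromatic ring, so no measured step bears directly on this change, and compound 3 carries a different group at that ring position together with a different chain. With nothing in the measured steps to point one way or the other, the step of a number 3 percentage points higher from compound 2 to compound 4 (within the scatter) is expected to stay within the scatter. Compound 4 is therefore estimated to give 46%, between 26% and 66%.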

Compound 4, percent of the compound remaining: 66%
For compound 4 the middle estimate is 20 percentage points below the measured one, and the stated range covers the measured number.
By their numbers in this assay, from the lowest: compound 3; then compounds 2 and 1 (each within the scatter of the next); then compound 4.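

Replacing the methoxy with hydrogen on this aromatic carbon, ortho to a large group and meta to a carboxy group, gives in this assay a number 23 percentage points higher from compound 2 to compound 4 (beyond the scatter). Among these compounds, this shows that the read-out responds to this ring position, whereas the only earlier step, a number 6 percentage points lower from compound 1 to compound 2 (within the scatter), at a saturated chain carbon, stayed within the scatter. Nothing available gives a measured basis for explaining the rise.

The compounds shown leave open how a fluorine or an ethoxy group on this same carbon would read, and whether hydrogen in place of methoxy would give a similar step alongside the chain of compound 1. Compound 3 carries chlorine at this position but also differs in its chain, so it cannot settle what that ring substituent alone does.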